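From a hydroxycyclohexyl side group to oxan-4-yl

The source may report more compounds than this note shows. Statements on the series, on what has been measured and on what is new or still open speak of the compounds shown alone.

Measured in an ADME assay on S9 fraction from liver (Rattus norvegicus) for metabolic stability, with a stated time of 1 h (on this read-out lower numbers stand for a less stable compound and higher numbers for a more stable compound), so far:
Compound 1 `N#Cc1cnc(NCc2cnccc2C(F)(F)F)cc1NC[C@H]1C[C@@H](O)C1` gives 44% 
Compound 2 `CO[C@H]1CC[C@@H](Nc2cc(NCc3cnccc3C(F)(F)F)ncc2C#N)CC1` gives 1% 
Compound 3 `N#Cc1cnc(NCc2cnccc2C(F)(F)F)cc1NC[C@H]1CC[C@H](O)CC1` gives 6% 

Compound 3 sits at the low end of this small series together with compound 2, well short of compound 1. Two steps show this: a number 5 percentage points higher from compound 2 to compound 3 (within the scatter) stays within the scatter, while a number 38 percentage points lower from compound 1 to compound 3 (beyond the scatter) is large. The next compound is compound 4 `N#Cc1cnc(NCc2cnccc2C(F)(F)F)cc1NC1CCOCC1`, and its change is oxan-4-yl in place of (4-hydroxycyclohexyl)methyl on a nitrogen on an aromatic ring on a nitrogen on an aromatic ring. Within the data shown here, two measured steps bear on it, a number 43 percentage points lower from compound 1 to compound 2 (beyond the scatter) and a number 38 percentage points lower from compound 1 to compound 3 (beyond the scatter), both large, and both end at a compound with a six-membered ring of carbon only. Among the measured compounds shown here, compound 4 has no such ring, yet its ring keeps six members, and no measured step covers a ring with a hetero atom. A moderate gain is therefore expected, estimated as a number 19 percentage points higher from compound 3 to compound 4 (beyond the scatter) in this assay and smaller than those large steps. For compound 4 the estimated value is 25%, with a range from 6% to 55% as the expected span.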

Compound 4, percent of the compound remaining: 17%
Compound 4: the middle estimate sits 8 percentage points above what was measured; measured number inside the range.
By their numbers in this assay, from the lowest: compounds 2 and 3 (each within the scatter of the next); then compound 4; then compound 1.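

In this assay, among these compounds, oxan-4-yl is the first group on this nitrogen whose six-membered ring holds a hetero atom, and it stands clear of both carbon-only rings: a number 11 percentage points higher from compound 3 to compound 4 (beyond the scatter), and a number 16 percentage points higher from compound 2 to compound 4 (beyond the scatter). The second of these steps matters most, as 4-methoxycyclohexyl also sits directly on the nitrogen, with no chain carbon in (4-hydroxycyclohexyl)methyl's manner, yet the six-membered oxan-4-yl does not match the cyclobutyl group, with a number 27 percentage points lower from compound 1 to compound 4 (beyond the scatter). Nothing measured here explains these differences.

Open, going by these compounds, is whether the ring oxygen itself or the removal of the methoxy or hydroxy group accounts for the rise. Oxan-4-ylmethyl, or piperidin-4-yl with a nitrogen in the ring, would test how far the trend extends.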